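The source may report more compounds than this note shows. Statements on the series, on what has been measured and on what is new or still open speak of the compounds shown alone.

Compound 1 `O=C(CCCCCC(=O)Nc1nnc(-c2ccncc2)s1)NO`: > 60000 nM
Compound 2 `O=C(CCCCCCC(=O)Nc1nnc(-c2ccncc2)s1)NO`: 7750 nM

In a functional assay on PC-3 cells (Homo sapiens) for antiproliferative activity, read by MTT assay, with a stated time of 48 h (on this read-out higher numbers stand for weaker inhibition and lower numbers for stronger inhibition), compound 1 gives > 60000 nM, which is a limit of the assay and not a number. For the measured compounds named here, compound 2, at 7750 nM, holds the only true number so far, so there is little to compare it with. Compound 3 `O=C(CCCCCCC(=O)Nc1nnc(-c2cccnc2)s1)NO` keeps the chain of compound 2 and alters only the aromatic group at the far end: pyridin-3-yl in place of pyridin-4-yl on an aromatic carbon. In words, pyridin-3-yl stands in place of pyridin-4-yl on an aromatic carbon. Going by the values given here, the one measured step, an at least 7.7-fold lower number from compound 1 to compound 2 (0.88 log units; beyond the scatter), changes the chain and leaves this group untouched, so it offers no direct guide to the size of this change. The value of compound 2, 7750 nM, therefore serves as the starting point. An estimated 1.0-fold lower number from compound 2 to compound 3 (0.01 log units; within the scatter) is expected, with no step beyond the scatter and no favoured direction. For compound 3, the expected value is 7500 nM, with an estimated range of 2500 nM to 22000 nM.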

Compound 3, half-maximal inhibitory concentration: 7980 nM
Compound 3: the middle estimate sits 1.1-fold (0.03 log units) below what was measured; the range from low to high includes it.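

Placing pyridin-3-yl where pyridin-4-yl stood, on the aromatic carbon of the five-membered ring, gives in this assay a 1.0-fold higher number from compound 2 to compound 3 (0.01 log units; within the scatter). For the compounds shown here, the earlier step changed only the chain, so this is the first reading on the aromatic group at the far end of the molecule. Within the scatter, compound 2 and compound 3 cannot be told apart on this read-out, so these two pyridine attachments make no visible difference here.

From the compounds shown here alone, whether a pyridin-2-yl group, a plain phenyl ring or a phenyl ring carrying an amine would also leave the number in place stays open, as does the outcome of a longer chain. Compound 1 stands at a limit of the assay and not at a number, so the full size of the chain step stays open as well: the limit of > 60000 nM in this assay, at which 1 of the 3 values shown sits.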